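A few compounds are considered here, and "the series" means these few. Any claim that something is new, unique, unknown or untested is made for them only; others in the source may bear on it.

Among the compounds with values here, compound 3 `C=CC(=O)Nc1cccc(NC(=O)CSc2nc(Nc3cccc([N+](=O)[O-])c3)c3ccccc3n2)c1` gives 22600 nM in a functional assay on NCI-H1975 cells (Homo sapiens) for inhibition, read by MTT assay, with a stated time of 72 h (on this read-out higher numbers stand for weaker inhibition and lower numbers for stronger inhibition), the highest of the three numbers so far. Compound 1 `C=CC(=O)Nc1cccc(NC(=O)CSc2nc(Nc3ccccc3F)c3ccccc3n2)c1` gives 6580 nM and compound 2 `C=CC(=O)Nc1cccc(NC(=O)CSc2nc(Nc3ccccc3Cl)c3ccccc3n2)c1` gives 10000 nM in this assay. Within the data shown here, two steps bear on the next change, a 3.4-fold higher number from compound 1 to compound 3 (0.54 log units; beyond the scatter) and a 2.3-fold higher number from compound 2 to compound 3 (0.35 log units; beyond the scatter); the third, a 1.5-fold higher number from compound 1 to compound 2 (0.18 log units; within the scatter), stayed within the scatter. Compound 4 `C=CC(=O)Nc1cccc(NC(=O)CSc2nc(Nc3cccc(C)c3)c3ccccc3n2)c1` carries methyl in place of nitro on an aromatic carbon. Among the measured compounds shown here, no measured pair swaps nitro for methyl directly, but both steps that introduced the 3-nitrophenyl group raised the number, so moving away from nitro is expected to lower it modestly in this assay, toward where compound 1 and compound 2 stand. For compound 4 this means an expected step of a 2.3-fold lower number from compound 3 to compound 4 (0.35 log units; beyond the scatter). Compound 4 is therefore estimated at 10000 nM, within a range of 4000 nM to 25000 nM.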

Compound 4, half-maximal inhibitory concentration: 12100 nM
The estimate for compound 4 lay 1.2-fold (0.08 log units) below the measured number; measured number inside the range.
By their numbers in this assay, from the lowest: compounds 1, 2, 4 and 3 (each within the scatter of the next, the first and the last beyond it).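

In this assay, methyl in place of nitro on an aromatic carbon stays within the scatter (a 1.9-fold lower number from compound 3 to compound 4 (0.27 log units; within the scatter)), so this swap at this position does not separate the two compounds. The 3-methylphenyl group also stays within the scatter of both halogenated anilines (a 1.2-fold higher number from compound 2 to compound 4 (0.08 log units; within the scatter); a 1.8-fold higher number from compound 1 to compound 4 (0.26 log units; within the scatter)), whereas 3-nitrophenyl lay beyond the scatter of both. No measurement at hand accounts for these numbers. Going by these compounds, whether an amine or a carboxylic acid at this position would shift the number beyond the scatter remains open.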